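Fluoro for isopropyl on an inactive anilino-lactam scaffold

The source may report more compounds than this note shows. Statements on the series, on what has been measured and on what is new or still open speak of the compounds shown alone.

Of the compounds shown here, three have been tested in a functional assay on MGC-803 cells (Homo sapiens) for antiproliferative activity, read by MTT assay, with a stated time of 72 h (a higher number here means a weaker inhibitor, a lower number a stronger inhibitor), so far, all of them sharing a lactam-bearing amide. Compound 1 `O=C(COc1ccc(C(=O)/C=C/c2ccc(F)c(F)c2)cc1)N[C@H]1CCOC1=O` carries a fluorinated cinnamoyl arm. In this assay compound 1 gives only a limit, > 64000 nM. Compound 2 `CC(C)c1ccc(NCC(=O)N[C@H]2CCOC2=O)cc1` links the lactam amide to an isopropyl-substituted aniline. In this assay compound 2 likewise reaches only a limit, > 64000 nM. Compound 3 `CCOc1ccccc1OCCSC(=S)N[C@H]1CCOC1=O` replaces the amide with a dithiocarbamate. In this assay compound 3 also stops at a limit, > 64000 nM. Compound 2 therefore stands nowhere above or below its companions: every value shown is the same limit, and the limit of > 64000 nM in this assay, at which 3 of the 3 values shown sit, is all the numbers say.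

The next compound, compound 4 `O=C(CNc1ccc(F)cc1)N[C@H]1CCOC1=O`, differs from compound 2 by fluoro in place of isopropyl on an aromatic carbon, so fluoro in place of isopropyl on an aromatic carbon. Going by the values given here, no measured pair shows what such a swap does here. With compound 2 sitting at > 64000 nM, a reading at the limit is again expected, and the step from compound 2 to compound 4 is expected to be a step that the limit leaves unreadable from compound 2 to compound 4. Compound 4 is thus estimated at 100000 nM, with a range from 30000 nM to 300000 nM.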

Compound 4, half-maximal inhibitory concentration: > 64000 nM
Compound 4 ended at the assay's limit (the forecaster's own chance of this, stated with the estimate: 85%); the middle value does not contradict the limit.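

Going by these compounds alone, compound 2 and compound 4 each give only a limit in this assay, not a number, so the swap of isopropyl for fluoro yields no step that can be read. The compounds shown leave open whether any change to these structures would bring a measurable value in this assay.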